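Replacing the Carbamoyl of Compound 3

The compounds below may be only part of what the source reports. "The series", "measured", "known", "first", "only" and "open" are said of these compounds alone.

In an ADME assay on BHK-21 cells (Mesocricetus auratus) for cytotoxicity, read by MTT assay (a lower number here means that less compound is tolerated, a higher number that more compound is tolerated), compound 3 (`COc1ccc(-c2nc3cc(/C(C)=N/NC(N)=O)ccc3[nH]2)c(OC)c1`) stands at >= 100000 nM as a limit and not a number. Compound 1 (`COc1ccc(-c2nc3cc(C(C)O)ccc3[nH]2)c(OC)c1`) also gives only a limit, > 100000 nM in this assay for that compound. Compound 2 (`COc1ccc(-c2nc3cc(/C(C)=N/NC(N)=O)ccc3[nH]2)cc1`) offers no help, its entry reading "not determined" (no result reported) in this assay and so giving no number. The next compound is compound 4 (`COc1ccc(-c2nc3cc(/C(C)=N/NC(N)=S)ccc3[nH]2)c(OC)c1`), which differs from compound 3 in a single place. The change is a group of 3 heavy atoms (1 carbon, 1 nitrogen, 1 sulfur; no ring) in place of a group of 3 heavy atoms (1 carbon, 1 nitrogen, 1 oxygen; no ring), on an amine nitrogen and the carbamoyl is the group that leaves.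

Among the measured compounds shown here, only one measured step touches compound 3, namely a step that the two limits leave unreadable from compound 1 to compound 3 in this assay and it concerns a different group, so it supplies no size to carry over. For the measured compounds named here, no measured pair makes this exchange. The expected change is therefore none beyond the scatter, and the estimated step is an at least 1.2-fold lower number from compound 3 to compound 4 (0.09 log units; that floor lies within the scatter) in this assay on that basis. In this assay compound 4 is expected at 80000 nM (estimated range 25000 nM to 130000 nM) if a number is reported at all.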

Compound 4, half-maximal cytotoxic concentration: 28000 nM
Estimate against measurement, compound 4: 2.9-fold (0.46 log units) above; the range from low to high includes it.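

Among the compounds shown here, compound 4 is the first compound here to give a number rather than a limit in this assay, and the exchange of carbamoyl for the sulfur-bearing group on the amine nitrogen gives an at least 3.5-fold lower number from compound 3 to compound 4 (0.55 log units; beyond the scatter), the first readable step at this position. With the heavy-atom count of the group unchanged and sulfur in the place of oxygen, that single exchange is enough to bring a number into view, and the change on the aromatic carbon reads the same way, an at least 3.5-fold lower number from compound 1 to compound 4 (0.55 log units; beyond the scatter). The true size of the first step stays open because compound 3 gives only a limit and not a number: the limit of >= 100000 nM in this assay, at which 1 of the 4 values shown sits.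

From the compounds shown here alone, how an acetyl group or a plain methyl on the amine nitrogen would read in this assay remains open. Going by these compounds, whether the exchange acts alike on the core of compound 2 also stays unknown, as the entry for compound 2 gives no number.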